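The source may hold more compounds than are shown below. What is called first, only, known or untested is meant among the compounds shown, and "the series" means these compounds.

In an ADME assay on Huh-7 cells (Homo sapiens) for cytotoxicity, read by MTT assay, with a stated time of 96 h (a lower number here means that less compound is tolerated, a higher number that more compound is tolerated), compound 1 `COc1cc(NCc2ccc(C)o2)ccc1-c1cnco1` gives 63400 nM and compound 2 `COc1ccc(-c2cnco2)cc1NCc1ccc(C)s1` gives 52900 nM, two numbers within the usual scatter of each other. Compound 3 `COc1cc(/N=C/c2cccs2)ccc1-c1cnco1` reads > 100000 nM, which is a limit of the assay and not a number. Compound 4 `COc1cc(NCc2scnc2C)ccc1-c1cnco1` has not yet been measured. It carries 4-methyl-1,3-thiazol-5-yl in place of 5-methylfuran-2-yl on a saturated chain carbon bound to a nitrogen on an aromatic ring. For the measured compounds named here, no measured pair shows this kind of change, so in this assay no shift beyond the scatter is expected. The expected step is a 1.1-fold higher number from compound 1 to compound 4 (0.04 log units; within the scatter), a slight move towards a higher number. The estimate for compound 4 is 70000 nM, with an expected range from 35000 nM to 100000 nM.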

Compound 4, half-maximal cytotoxic concentration: 58500 nM
The estimate for compound 4 lay 1.2-fold (0.08 log units) above the measured number; low and high end bracket the measured number.
By their numbers in this assay, from the lowest: compounds 2, 4 and 1 (each within the scatter of the next). At a limit, above all of these: compound 3.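

In this assay, for the compounds shown here, the exchange of 5-methylfuran-2-yl for 4-methyl-1,3-thiazol-5-yl gives the first step that can be read at this place, on a saturated chain carbon bound to a nitrogen on an aromatic ring: a 1.1-fold lower number from compound 1 to compound 4 (0.03 log units; within the scatter). So a ring with 2 hetero atoms and 2 hydrogen-bond acceptors reads the same here as one with 1 hetero atom and 1 acceptor. Nothing measured here gives a cause for this. This single pair leaves open how a group other than a five-membered aromatic ring would read at this place, such as a carboxylic acid or an amine.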